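A Second Methoxy Group on the Shared Core

The compounds below may be only part of what the source reports. "The series", "measured", "known", "first", "only" and "open" are said of these compounds alone.

Compound 1 `COc1cccc2c1OCN(c1ccc3oc(-c4ccccc4)cc(=O)c3c1)C2` sits in the middle of three compounds tested in a functional assay on MCF7 cells (Homo sapiens) for inhibition, read by MTT assay, with a stated time of 48 h, tested at 15 ug/mL; a higher number here means more inhibition of growth at the concentration tested, a lower number less inhibition of growth. Compound 1 gives 54%. Compound 2 `O=c1cc(-c2ccccc2)oc2ccc(N3COc4c(cccc4[N+](=O)[O-])C3)cc12`, which carries a nitro in place of methoxy on an aromatic carbon, gives 55.9%, a change of a number 1.9 percentage points higher from compound 1 to compound 2 (within the scatter). Compound 3 `O=c1cc(-c2ccccc2)oc2ccc(N3COc4ccccc4C3)cc12`, with hydrogen in place of methoxy on an aromatic carbon, gives 34%, a change of a number 20 percentage points lower from compound 1 to compound 3 (beyond the scatter); from compound 2 the corresponding change is a number 21.9 percentage points lower from compound 2 to compound 3 (beyond the scatter).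

Compound 4 `COc1cc2c(c(OC)c1)OCN(c1ccc3oc(-c4ccccc4)cc(=O)c3c1)C2` differs from compound 1 by methoxy in place of hydrogen on an aromatic carbon, placed on an aromatic carbon of a six-membered aromatic ring of carbon only, part of a fused or bridged system of two rings, meta to the existing methoxy group. The two steps that bear on this change both show that removing a group from this ring lowers growth inhibition, as the step from compound 1 to compound 3 shows with a number 20 percentage points lower from compound 1 to compound 3 (beyond the scatter). Adding a group is expected to hold or slightly raise the number; the estimated step is a number 6 percentage points higher from compound 1 to compound 4 (within the scatter). Compound 4 is therefore expected to give about 60%, with a likely range from 45% to 75%.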

Compound 4, percent growth inhibition at one concentration: 60%
The estimate for compound 4 equals the measured number at the digits printed, within the range that was stated.
By their numbers in this assay, from the lowest: compound 3; then compounds 1, 2 and 4 (each within the scatter of the next).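

Placing a methoxy group on this carbon, meta to the methoxy group already on the ring, gives a number 6 percentage points higher from compound 1 to compound 4 (within the scatter) in this assay, so the two compounds cannot be told apart in this assay. The earlier steps shown here all concerned a single place on this ring, whereas this one shows that a second place can carry a methoxy group while growth inhibition stays within the scatter of compound 1. Nothing measured here offers an explanation for this result.

The compounds shown leave open whether an amine or a carboxylic acid on this same carbon would be tolerated as well as methoxy. They also leave open what a methoxy group here would do on a ring without the existing methoxy group.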